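Aryl substituent changes on the shared core and cytotoxicity

The source may report more compounds than this note shows. Statements on the series, on what has been measured and on what is new or still open speak of the compounds shown alone.

Measured compounds:
compound 1 `O=C(Nc1ccc(Oc2ccnc3[nH]ccc23)c(F)c1)c1nn(-c2ccc(Cl)cc2)ccc1=O`: > 60000 nM
compound 2 `COc1ccc(-n2ccc(=O)c(C(=O)Nc3ccc(Oc4ccnc5[nH]ccc45)c(F)c3)n2)cc1`: > 60000 nM
compound 3 `O=C(Nc1ccc(Oc2ccnc3[nH]ccc23)c(F)c1)c1nn(-c2ccccc2)ccc1=O`: 56800 nM

In a functional assay on A549 cells (Homo sapiens) for cytotoxicity, read by MTT assay, with a stated time of 72 h (a lower number here means a stronger inhibitor, a higher number a weaker inhibitor), compound 1 gives > 60000 nM, which is a limit of the assay and not a number. Compound 2 likewise gives > 60000 nM, again a limit. For the measured compounds named here, compound 3 gives 56800 nM, the only number among the three values. The values of compound 1 and compound 2 are recorded in the limit of > 60000 nM in this assay, at which 2 of the 3 values shown sit. The step of an at least 1.0-fold lower number from compound 1 to compound 3 (0.02 log units; that floor lies within the scatter) and the step of an at least 1.0-fold lower number from compound 2 to compound 3 (0.02 log units; that floor lies within the scatter) both sit at a floor within the scatter, so compound 3 cannot be called different from compound 1 or compound 2. The step that the two limits leave unreadable from compound 1 to compound 2 is not readable.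

Compound 4 `O=C(Nc1ccc(Oc2ccnc3[nH]ccc23)c(F)c1)c1nn(-c2ccc(Br)cc2F)ccc1=O` carries the change (4-bromo-2-fluorophenyl in place of phenyl on an aromatic nitrogen). Going by the values given here, the steps that bear on it are an at least 1.0-fold lower number from compound 1 to compound 3 (0.02 log units; that floor lies within the scatter) and an at least 1.0-fold lower number from compound 2 to compound 3 (0.02 log units; that floor lies within the scatter), where chloro or methoxy on that ring gave only limits. A ring bearing bromo and fluoro is therefore expected to stay at or near the limit, with the step of a 1.1-fold higher number from compound 3 to compound 4 (0.06 log units; within the scatter) expected to lie within the scatter. Compound 4 is estimated at 65000 nM, between 30000 nM and 150000 nM, with a good chance that only a limit is reported.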

Compound 4, half-maximal inhibitory concentration: 55700 nM
Compound 4: middle estimate off by 1.2-fold (0.07 log units), on the high side, within the range that was stated.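

Replacing phenyl with 4-bromo-2-fluorophenyl on the aromatic nitrogen gives, in this assay, a 1.0-fold lower number from compound 3 to compound 4 (0.01 log units; within the scatter), so a ring carrying both bromo and fluoro reads the same as the plain phenyl ring within the scatter, and this position now has a second readable number, the first for a substituted ring. The comparisons with the other substituted rings, an at least 1.0-fold lower number from compound 2 to compound 4 (0.03 log units; that floor lies within the scatter) and an at least 1.0-fold lower number from compound 1 to compound 4 (0.03 log units; that floor lies within the scatter), rest only on floors within the scatter, so compound 4 cannot be told apart from compound 1 or compound 2. Compound 1 and compound 2 each remain at a limit of the assay and not at a number: the limit of > 60000 nM in this assay, at which 2 of the 4 values shown sit.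

The compounds shown leave open whether any group on this aryl ring can move the reading beyond the scatter, for example an amine or a carboxylic acid at the place held by bromo, or a longer chain in place of the aryl ring itself. They also leave open how the reading responds to changes elsewhere on the shared core, such as replacing the fluoro on the central ring with a nitrile.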